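A Diethylamino Group Replaces a Chlorinated Side Chain

The source may hold more compounds than are shown below. What is called first, only, known or untested is meant among the compounds shown, and "the series" means these compounds.

Values in a functional assay for inhibition, with Homo sapiens as the target; a higher number here means that more compound is needed for the effect, a lower number that less compound is needed:
- compound 1 `CCCC(=O)Nc1ccc(C2=NNC(=O)CC2)cc1`: 1.44 ug/mL
- compound 2 `O=C1CCC(c2ccc(NC(=O)CCCCl)cc2)=NN1`: > 46.4 ug/mL (a limit of the assay, not a number)
- compound 3 `CC(C)(CCl)C(=O)Nc1ccc(C2=NNC(=O)CC2)cc1`: 11.4 ug/mL

Compound 3 gives 11.4 ug/mL and holds the higher of the two true numbers, with compound 1 nearest at 1.44 ug/mL as the lower one. Compound 2 gives > 46.4 ug/mL and this is a limit of the assay.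

Compound 4 `CCN(CC)CC(=O)Nc1ccc(C2=NNC(=O)CC2)cc1` has not yet been measured. It carries (diethylamino)methyl in place of 1-(chloromethyl)-1-methylethyl on a carbonyl carbon. Three measured steps changed the group on that carbonyl carbon. One shows a 7.9-fold higher number from compound 1 to compound 3 (0.90 log units; beyond the scatter) and is modest, another shows an at least 4.0-fold lower number from compound 2 to compound 3 (0.60 log units; beyond the scatter) and is at least modest, and the third shows an at least 32-fold higher number from compound 1 to compound 2 (1.50 log units; beyond the scatter) and is large. These steps run in both directions and none brings in (diethylamino)methyl, so they suggest the width of the expectation more than its direction. The expected step is a 1.8-fold lower number from compound 3 to compound 4 (0.24 log units; within the scatter) with a wide margin on either side. In this assay the estimated value for compound 4 is 6.5 ug/mL with an expected range of 1.2 ug/mL to 35 ug/mL as its two ends.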

Compound 4, half-maximal effective concentration: about 10 ug/mL
The estimate for compound 4 lay 1.5-fold (0.19 log units) below the measured number, and the stated range covers the measured number.
By their numbers in this assay, from the lowest: compound 1; then compounds 4 and 3 (each within the scatter of the next). At a limit, above all of these: compound 2.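

In this assay, (diethylamino)methyl, which carries no chlorine, lies within the scatter of the chlorinated 1-(chloromethyl)-1-methylethyl on the same carbonyl carbon: a 1.1-fold lower number from compound 3 to compound 4 (0.06 log units; within the scatter). The earlier compounds shown here could suggest that chlorine alone raised the number, but compound 4 goes against that reading, since it has no chlorine and still does not return to the number of the unchlorinated compound 1: a 6.9-fold higher number from compound 1 to compound 4 (0.84 log units; beyond the scatter). Starting from a limit of the assay, there is an at least 4.6-fold lower number from compound 2 to compound 4 (0.66 log units; beyond the scatter), so only a bound on the size of that step can be read: the limit of > 46.4 ug/mL in this assay, at which 1 of the 4 values shown sits.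

The compounds shown leave open whether a smaller dimethylamino group or a piperidine ring amine at this place would come closer to compound 1 at 1.44 ug/mL. They also leave open how a carboxylic acid at the end of the chain would fare.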